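Amino Added to the Core of Compound 1

The compounds below may be only part of what the source reports. "The series", "measured", "known", "first", "only" and "open" are said of these compounds alone.

Measured compounds:
compound 1 `Fc1cccc(F)c1C#Cc1cncc2ccccc12`: 87.9%
compound 2 `Fc1cccc(F)c1C#Cc1ccc2cn[nH]c2c1`: 97%

In a functional assay on LS174T cells (Homo sapiens) for inhibition, with a stated time of 4 days, tested at 10 uM (on this read-out lower numbers stand for a weaker effect and higher numbers for a stronger effect at the one concentration tested), compound 1 gives 87.9%. In this assay compound 2 gives 97%. The two numbers lie within the scatter of each other, so compound 1 stands level with compound 2 on what has been measured. For the measured compounds named here, no step between measured compounds that differ in one place is available.

Compound 3 `Nc1ncc(C#Cc2c(F)cccc2F)c2ccccc12` differs from compound 1 by amino in place of hydrogen on an aromatic carbon. Nothing measured shows what an amino at this place does, so the expected step from compound 1 to compound 3 is none beyond the scatter, and a number 1.9 percentage points lower from compound 1 to compound 3 (within the scatter) is what this estimate means. Compound 3 is therefore expected to give about 86% in this assay, in a range from 65% to 98%, because compound 1 already gives 87.9%.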

Compound 3, a percentage reported as inhibition, at one concentration (the size of the read-out at that concentration, not a potency): 93.1%
Estimate against measurement, compound 3: 7.1 percentage points below; the range from low to high includes it.
By their numbers in this assay, from the lowest: compounds 1, 3 and 2 (each within the scatter of the next).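

The core of compound 1 accepts amino in place of hydrogen on an aromatic carbon, next to the ring nitrogen, without a change that can be told from scatter: this assay shows a number 5.2 percentage points higher from compound 1 to compound 3 (within the scatter) at the one concentration tested. For the compounds shown here, this is the first reading for this position, and it shows that a group can stand on this carbon while the effect stays level with that of compound 1. Nothing given here accounts for the size of this step.

Going by these compounds, it remains open whether a methylamino group, a hydroxyl or an acetamide at the same place would also leave the effect level. On these data alone, because the read-out comes from one concentration, the potency of compound 1 and compound 3 also remains open.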